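A Piperazine Amide Follows the Acetoxyamino Compound

The source may report more compounds than this note shows. Statements on the series, on what has been measured and on what is new or still open speak of the compounds shown alone.

In a functional assay on NCI-H23 cells (Homo sapiens) for inhibition, read by ELISA, with a stated time of 24 h (on this read-out higher numbers stand for weaker inhibition of growth and lower numbers for stronger inhibition of growth), compound 1 `O=C(Cl)/C=C/c1ccccc1OC(=O)c1ccccc1` reaches only a limit, > 100000 nM. Among the measured compounds shown here, compound 2 `CC(=O)ONC(=O)/C=C/c1ccccc1OC(=O)c1ccccc1` gives 26300 nM, the only true number so far. For the measured compounds named here, the single measured step, an at least 3.8-fold lower number from compound 1 to compound 2 (0.58 log units; beyond the scatter), came with acetoxyamino in place of chloro on a carbonyl carbon. As far as these compounds go, its full size remains open, since one end of it rests on (the limit of > 100000 nM in this assay, at which 1 of the 2 values shown sits).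

Compound 3 `CN1CCN(C(=O)/C=C/c2ccccc2OC(=O)c2ccccc2)CC1` changes the same carbonyl carbon, with 4-methylpiperazin-1-yl in place of acetoxyamino on a carbonyl carbon. Going by the values given here, the step to compound 2 is the only guide, and it is a loose one, as it replaced chloro rather than acetoxyamino. It shows that this carbonyl substituent can move the read-out, but it gives no direction for the new group. Starting from compound 2 at 26300 nM, little change beyond the scatter is expected in this assay, with any drift more likely toward weaker inhibition. The expected step is a 1.5-fold higher number from compound 2 to compound 3 (0.18 log units; within the scatter). The estimated value for compound 3 is 40000 nM, with an expected range from 10000 nM to 100000 nM.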

Compound 3, concentration for 50% growth inhibition: > 100000 nM
Compound 3: only a limit was reported (the forecaster's own chance of this, stated with the estimate: 30%); middle value at least 2.5-fold (0.39 log units) away from the limit.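

With 4-methylpiperazin-1-yl in place of acetoxyamino on a carbonyl carbon, the result is an at least 3.8-fold higher number from compound 2 to compound 3 (0.58 log units; beyond the scatter), so a change from acetoxyamino at this place can also move the number toward weaker inhibition of growth. Among the compounds shown here, compound 3, like compound 1, reaches only a limit of the assay, which leaves acetoxyamino as the only one of the three groups at this carbonyl carbon to give a true number. The full size of the new step stays open, and the step from compound 1 to compound 3 cannot be read, because these comparisons rest on limits: the limit of > 100000 nM in this assay, at which 2 of the 3 values shown sit.

The three compounds leave open which part of acetoxyamino goes with the lower number, a question that a hydroxyamino group, a methoxyamino group or a plain amino group on the same carbonyl carbon could help to separate. They also do not tell whether a piperazine without the methyl group, or an open-chain dimethylamino group, would give a true number in this assay or remain at the limit.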